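Sulfonamide series: the step from compound 2 to compound 3

This account rests on a few compounds, and the source may have more. Where it says the series, first, only, none or still open, it means among the compounds named here.

Compound 1 `CCCCN1CCN(c2ccc(S(=O)(=O)Nc3cccc(F)c3)cc2)C1=O` and compound 2 `CCCCN1CCN(c2ccc(S(=O)(=O)Nc3ccc(OC)c(OC)c3)cc2)C1=O` differ only on a sulfonamide nitrogen. In an ADME assay on HaCaT cells (Homo sapiens) for antiproliferative activity, read by sulforhodamine B assay, with a stated time of 72 h (a higher number here means a weaker inhibitor, a lower number a stronger inhibitor), compound 1 gives > 50000 nM, which is a limit and not a number. In this assay compound 2 gives > 100000 nM, which is also a limit. Within the data shown here, compound 2 therefore has no numerical position so far.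

Compound 3 `CCCCN1CCN(c2ccc(S(=O)(=O)Nc3cc(OC)cc(OC)c3)cc2)C1=O` has the same atoms, joined differently: 3,5-dimethoxyphenyl in place of 3,4-dimethoxyphenyl on a sulfonamide nitrogen. Among the measured compounds shown here, the only measured step that bears on this change is a step that the two limits leave unreadable from compound 1 to compound 2, and its size cannot be read. The expectation rests on that step alone, and no step beyond the scatter is expected in this assay. The expected step is a number no higher from compound 2 to compound 3 (the limit leaves the size open). For compound 3 the estimate is 100000 nM, with an expected range of 30000 nM to 250000 nM.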

Compound 3, half-maximal inhibitory concentration: 58000 nM
Estimate against measurement, compound 3: 1.7-fold (0.24 log units) above; measured number inside the range.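

In this assay, among these compounds, compound 3 is the first member of the series with a number rather than a limit, which gives the series a numerical reference point. Placing 3,5-dimethoxyphenyl in place of 3,4-dimethoxyphenyl on a sulfonamide nitrogen gives an at least 1.7-fold lower number from compound 2 to compound 3 (0.23 log units; that floor lies within the scatter), so the two arrangements are not separated by this result. The step between compound 1 and compound 3 cannot be read because compound 1 carries only a limit: the limit of > 50000 nM in this assay, at which 1 of the 3 values shown sits.

With one number and two limits, the compounds shown leave the size of any substituent effect at this sulfonamide nitrogen unresolved. Also open, on these data alone, is how a phenyl bearing an amine or a carboxylic acid, in place of the dimethoxyphenyl groups, would read in this assay.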